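Ethyl to Methoxy on the Core of Compound 1

The source may hold more compounds than are shown below. What is called first, only, known or untested is meant among the compounds shown, and "the series" means these compounds.

Measured so far:
compound 1, `CCc1ccc(-c2nn3cc(-c4cccc(N)c4)nc3s2)cc1`, 8200 nM
compound 2, `C=C(Br)C(=O)Nc1cccc(-c2cn3c(-c4ccc(Cl)cc4)csc3n2)c1`, 1100 nM

In a functional assay on FM3A cells (Mus musculus) for inhibition, read by cell counting, with a stated time of 2 days (a lower number here means a stronger inhibitor, a higher number a weaker inhibitor), compound 1 gives 8200 nM, the highest of the two numbers; compound 2 gives 1100 nM, a gap beyond the scatter. Within the data shown here, the two measured compounds differ in several places, so no single step is known. Compound 3, `COc1ccc(-c2nn3cc(-c4cccc(N)c4)nc3s2)cc1`, differs from compound 1 by methoxy in place of ethyl on an aromatic carbon. Among the measured compounds shown here, with no comparable step measured, the size of a 1.0-fold lower number from compound 1 to compound 3 (0.01 log units; within the scatter) is expected to be none beyond the scatter, in either direction. Compound 3 is estimated at 8000 nM, within 3000 nM to 25000 nM.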

Compound 3, half-maximal inhibitory concentration: 74000 nM
The estimate for compound 3 lay 9.3-fold (0.97 log units) below the measured number; measured number outside the range, above it.
By their numbers in this assay, from the lowest: compound 2; then compound 1; then compound 3.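

Among these compounds, this is the first step in one place at this position: with methoxy in place of ethyl, both of the same heavy-atom count, this assay shows a 9.0-fold higher number from compound 1 to compound 3 (0.96 log units; beyond the scatter) on the shared core. The aromatic carbon para to a large group therefore does not treat these two groups alike, and the number rises with the group that brings a hydrogen-bond acceptor, though this rests on a single step. Nothing measured here explains the rise.

Going by these compounds, whether an amine or a longer chain at this carbon would stand nearer to ethyl or to methoxy remains open. Also open, on these data alone, is whether the same change would move the number in the same way on the core of compound 2.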